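The source may report more compounds than this note shows. Statements on the series, on what has been measured and on what is new or still open speak of the compounds shown alone.

Compound 1 `COc1ccc(/C=C/C(=O)c2ccc(N3CCN(c4ccc(Cl)c(Cl)c4)CC3)cc2)cc1OC`: 63.5%
Compound 2 `COc1ccc(/C=C/C(=O)c2ccc(N3CCN(S(=O)(=O)c4ccc(Br)cc4)CC3)cc2)cc1OC`: 75.5%

In a functional assay on the whole organism (strain Kunming) for inhibition, with Mus musculus as the target, with a stated time of 1 h, at a dose of 40 mg/kg by the oral route (on this read-out higher numbers stand for more inhibition at the one dose given (going by the name of the read-out) and lower numbers for less inhibition), compound 2 stands highest of the two numbers, giving 75.5%, while compound 1 gives 63.5%. Among the compounds with values here, the one measured step is a number 12 percentage points higher from compound 1 to compound 2 (beyond the scatter). Compound 3 `COc1ccc(S(=O)(=O)N2CCN(c3ccc(C(=O)/C=C/c4ccc(OC)c(OC)c4)cc3)CC2)cc1` differs from compound 2 by methoxy in place of bromo on an aromatic carbon. Within the data shown here, no measured step alters the (4-bromophenyl)sulfonyl group itself, so the only known step bears on a different part of the molecule and gives no direct guide. With nothing pointing either way, no change beyond the scatter is expected. Compound 3 is therefore estimated at 72%, with a range from 55% to 88%, which means an expected step of a number 3.5 percentage points lower from compound 2 to compound 3 (within the scatter).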

Compound 3, a percentage reported as inhibition, in the whole organism at one dose (the size of the read-out at that dose, not a potency): 64.1%
The estimate for compound 3 lay 7.9 percentage points above the measured number, within the range that was stated.
By their numbers in this assay, from the lowest: compounds 1 and 3 (each within the scatter of the next); then compound 2.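

In this assay, the group on the far end of the sulfonyl ring matters: methoxy in place of bromo brings a number 11.4 percentage points lower from compound 2 to compound 3 (beyond the scatter), so the sulfonyl link alone does not secure the higher number. With (4-methoxyphenyl)sulfonyl in place of 3,4-dichlorophenyl, the result is a number 0.6 percentage points higher from compound 1 to compound 3 (within the scatter), so these two groups cannot be told apart here. No measurement at hand accounts for the difference between bromo and methoxy. From the compounds shown here alone, whether chloro, an amine or a carboxylic acid at this place would match bromo or methoxy remains open.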